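The source may hold more compounds than are shown below. What is called first, only, known or untested is meant among the compounds shown, and "the series" means these compounds.

Working notes on the series. Three compounds have numbers in a functional assay on SK-BR-3 cells (Homo sapiens) for antiproliferative activity, read by MTT assay, with a stated time of 72 h; on this read-out higher numbers stand for weaker inhibition and lower numbers for stronger inhibition. Compound 1 `COc1cccc(CNc2ncnc3ccc(-c4cnn(C)c4)cc23)c1` gives 36000 nM; compound 3 `Cn1cc(-c2ccc3ncnc(Oc4ccc5ncccc5c4)c3c2)cn1` gives 14400 nM; compound 2 `CC(Nc1nc(N)nc2ccc(-c3cnn(C4CCNCC4)c3)cc12)c1c(Cl)ccc(F)c1Cl` gives 1580 nM, the lowest of the three, with compound 3 the nearest of the others and compound 1 the furthest, both gaps beyond the scatter. Compound 4 `CC(Nc1nc(N)nc2ccc(-c3cnn(C)c3)cc12)c1c(Cl)ccc(F)c1Cl` has not yet been measured. It differs from compound 2 in one place: methyl in place of piperidin-4-yl on an aromatic nitrogen. Among the compounds with values here, no pair of measured compounds isolates this change. Compounds 1 and 3 do carry methyl on a ring nitrogen of the same kind, but on other cores, so their numbers say nothing clean about what the piperidin-4-yl contributes to compound 2. With nothing in the series to anchor it, the step of a 2.2-fold higher number from compound 2 to compound 4 (0.35 log units; beyond the scatter) is expected to be a moderate shift toward a higher number, that is weaker inhibition, probably beyond the scatter but not by much. Compound 4 is accordingly estimated at 3500 nM, with 1200 nM to 12000 nM as the expected range.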

Compound 4, half-maximal inhibitory concentration: 7140 nM
Beside the measured number, compound 4's estimate is 2.0-fold (0.31 log units) below it, within the range that was stated.
By their numbers in this assay, from the lowest: compound 2; then compounds 4 and 3 (each within the scatter of the next); then compound 1.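

In this assay, the change from 1-(piperidin-4-yl)-1H-pyrazol-4-yl to 1-methyl-1H-pyrazol-4-yl now has its first clean reading, with a 4.5-fold higher number from compound 2 to compound 4 (0.66 log units; beyond the scatter) on an otherwise unchanged structure. The position is therefore not indifferent to what it carries: on this aromatic nitrogen, piperidin-4-yl goes with stronger inhibition than methyl, though the step is modest. No supporting measurement bears on the cause of this step.

The step changes the ring, the ring nitrogen and the size of the group all at once, so it cannot say which of these matters. Still open, on these data alone, is whether cyclohexyl, which keeps a six-membered ring without the nitrogen, or a 2-aminoethyl chain, which keeps an amine without the ring, would stay closer to piperidin-4-yl or to methyl.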